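The source may hold more compounds than are shown below. What is called first, only, known or untested is meant among the compounds shown, and "the series" means these compounds.

Measured so far:
compound 1, `COc1ccc(-c2cc(/C=C/C(=O)c3ccc(C)cc3)nc3cc(-c4ccccc4)nn23)cc1OC`, 26800 nM
compound 2, `COc1cc(-c2cc(/C=C/C(=O)c3ccc(C)cc3)nc3cc(-c4ccccc4)nn23)cc(OC)c1OC`, 27100 nM
compound 3, `COc1ccc(C(=O)/C=C/c2cc(-c3ccc(OC)cc3)n3nc(-c4ccccc4)cc3n2)cc1`, 8500 nM

The three measured compounds were tested in a functional assay on DU-145 cells (Homo sapiens) for antiproliferative activity, read by MTT assay, with a stated time of 24 h; a lower number here means a stronger inhibitor, a higher number a weaker inhibitor. Compound 1 gives 26800 nM, compound 2 gives 27100 nM, and compound 3 gives 8500 nM, the lowest of the three numbers, lying beyond the scatter from the other two.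

Compound 1 differs from compound 2 in one place, (hydrogen in place of methoxy on an aromatic carbon), and in this assay that change gave a 1.0-fold lower number from compound 2 to compound 1 (0.00 log units; within the scatter). Compound 3 and compound 2 differ in more than one place, and the difference between their cores is not broken down here.

The unmeasured compound 4, `COc1ccc(-c2cc(/C=C/C(=O)c3ccccc3)nc3cc(-c4ccccc4)nn23)cc1`, differs from compound 3 by hydrogen in place of methoxy on an aromatic carbon. For the measured compounds named here, this is the same kind of change as the one from compound 2 to compound 1, but not the same: in compound 2 the leaving methoxy sits ortho to a methoxy group, meta to a large group and meta to a methoxy group, whereas in compound 3 it sits para to a large group. Because a 1.0-fold lower number from compound 2 to compound 1 (0.00 log units; within the scatter) was flat, the step from compound 3 to compound 4 is expected to be small as well, a 1.3-fold higher number from compound 3 to compound 4 (0.11 log units; within the scatter), with wider uncertainty given the different surroundings. Compound 4 is therefore estimated at 11000 nM in this assay, within a range from 4000 nM to 30000 nM.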

Compound 4, half-maximal inhibitory concentration: 13700 nM
Beside the measured number, compound 4's estimate is 1.2-fold (0.10 log units) below it; low and high end bracket the measured number.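

In this assay, the change from (4-methoxyphenyl)carbonyl to benzoyl gave a 1.6-fold higher number from compound 3 to compound 4 (0.21 log units; within the scatter). Set beside the earlier step, hydrogen in place of methoxy on an aromatic carbon shows no difference between the two cores: the same change on two cores in this assay, a 1.0-fold lower number (0.00 log units; within the scatter) from compound 2 to compound 1 and a 1.6-fold higher number (0.21 log units; within the scatter) from compound 3 to compound 4, 1.6-fold (0.21 log units) apart, within the scatter of two such steps This supports carrying the change from one core to the other in this series as a small step in this assay, but it rests on only two pairs, in which the methoxy group leaves different surroundings, and it does not show that the same would hold at other places on the aromatic rings or on other cores.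

The compounds shown leave open what happens when the methoxy group gives way to something other than hydrogen, such as a fluorine or chlorine atom, an amine, a carboxylic acid or a longer chain such as ethoxy or butoxy. They also leave open whether any replacement at these places would move the number beyond the scatter, since both hydrogen-for-methoxy steps shown here stay within it.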